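A Methyl for a Chloro at the Assay Limit

This account rests on a few compounds, and the source may have more. Where it says the series, first, only, none or still open, it means among the compounds named here.

Compound 1 `Cc1ccnc2nc(-c3cccc(Cl)c3)cc(O)c12` gives 11.8 nM in this series
Compound 2 `Cc1ccc2c(O)cc(-c3cccc(Cl)c3)nc2n1` gives > 100000 nM in this series

Among the measured compounds shown here, both values come from a functional assay on MDA-N cells (Homo sapiens) for antiproliferative activity (a lower number here means a stronger inhibitor of growth, a higher number a weaker inhibitor of growth), and only two compounds have been measured so far. Compound 2 stands at > 100000 nM as a limit of the assay and not as a number. For the measured compounds named here, compound 3 `Cc1cccc(-c2cc(O)c3ccc(C)nc3n2)c1` has methyl in place of chloro on an aromatic carbon as its one difference from compound 2. Going by the values given here, no measured step shows what this exchange does in this assay so its size can only be estimated. No change beyond the scatter is expected, with a small gain in potency as the less likely outcome. Compound 3 is expected to remain a very weak inhibitor of growth. The estimated move an at least 1.4-fold lower number from compound 2 to compound 3 (0.15 log units; that floor lies within the scatter) is therefore small. For compound 3 the estimate is 70000 nM with an expected range from 8000 nM to 100000 nM in this assay.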

Compound 3, concentration for 50% growth inhibition: 31.6 nM
Estimate against measurement, compound 3: 2200-fold (3.35 log units) above; the whole stated range lies above it.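

In this assay, among the compounds shown here, methyl in place of chloro on this aromatic carbon, meta to a large group, gives the first step that can be read: an at least 3100-fold lower number from compound 2 to compound 3 (3.50 log units; beyond the scatter). The position is therefore far from indifferent to what it carries, since neither chloro nor methyl brings a ring, a hydrogen-bond donor, a hydrogen-bond acceptor or a net charge, and this single exchange alone moves the compound away from the limit. Compound 2 remains a limit of the assay and not a number, so the step gives only a floor for the true size of the change: the limit of > 100000 nM in this assay, at which 1 of the 3 values shown sits.

On these data alone, whether the gain is particular to methyl or would also appear with another group here, such as methoxy or an amine, stays open. Also open, as far as these compounds go, is whether the same exchange would act alike on compound 1, whose methyl sits elsewhere on the core.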